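The source may report more compounds than this note shows. Statements on the series, on what has been measured and on what is new or still open speak of the compounds shown alone.

Measured so far
- compound 1, `COc1ccc(N2CCN(Cc3csc(N)c3C(=O)c3ccc(Cl)cc3)CC2)cc1`: 0%
- compound 2, `Nc1scc(CN2CCC(c3ccc(Cl)cc3)CC2)c1C(=O)c1ccc(Cl)cc1`: 6%

Both compounds share a core built around an aminothiophene bearing a 4-chlorobenzoyl group, and both were tested in an assay on CHO cells for displacement of a labelled ligand from adenosine receptor A3 (Homo sapiens), read by scintillation counting, with a stated time of 120 min, tested at 10 uM; on this read-out lower numbers stand for less inhibition and higher numbers for more inhibition at the one concentration tested (going by the name of the read-out). Compound 1 gives 0% in this assay, and compound 2 gives 6%. Going by the values given here, the gap between the two is within the usual scatter of this read-out, so compound 1 cannot be told apart from compound 2 on these numbers; no step between measured compounds is available, and the series so far shows essentially no inhibition at the concentration tested.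

Compound 3, `Nc1scc(CN2CCN(C3CCCCCC3)CC2)c1C(=O)c1ccc(Cl)cc1`, has not been measured yet. It differs from compound 1 in one place: cycloheptyl in place of 4-methoxyphenyl on an amine nitrogen in a ring. Among the compounds with values here, with no measured step to lean on, the expectation rests only on the two measured values, which both sit near the floor of the read-out. Compound 3 is therefore expected to stay at a low level of inhibition, with the step from compound 1 being small and not clearly beyond the scatter, a number 10 percentage points higher from compound 1 to compound 3 (within the scatter). The estimate for compound 3 in this assay is 10%, with a range from 0% to 30%.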

Compound 3, a percentage reported as inhibition, at one concentration (the size of the read-out at that concentration, not a potency): 0%
Compound 3: middle estimate off by 10 percentage points, on the high side; the range from low to high includes it.
By their numbers in this assay, from the lowest: compounds 1, 3 and 2 (each within the scatter of the next).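

In this assay, going by these compounds alone, the change on the amine nitrogen in the ring gives no change at the digits printed from compound 1 to compound 3 (within the scatter), the first single-place comparison. Cycloheptyl, with its seven-membered non-aromatic ring of carbon only, reads the same as 4-methoxyphenyl, with its six-membered aromatic ring and hydrogen-bond acceptor, so neither the aromatic ring nor the acceptor separates this pair on these numbers. Compound 1 and compound 3 both give a reading at the bottom of the scale, which leaves the comparison able to show only a gain at this position, and no measurement available here accounts for the absence of one.

On these data alone, whether any group on this nitrogen can raise inhibition at the one concentration tested stays open, for instance a carboxylic acid or a longer chain ending in an amine. Also open, as far as these compounds go, is whether a change elsewhere on the shared core, such as an acetyl in place of the 4-chlorobenzoyl group, would move the read-out at all.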